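The source may report more compounds than this note shows. Statements on the series, on what has been measured and on what is new or still open speak of the compounds shown alone.

Measured so far:
compound 1, `CCSc1nc(NC(C)c2ccccc2)c2ncn([C@@H]3O[C@H](CO)[C@@H](O)[C@H]3O)c2n1`: 197000 nM
compound 2, `CCCCSc1nc(NCc2ccccc2)c2ncn([C@@H]3O[C@H](CO)[C@@H](O)[C@H]3O)c2n1`: 202000 nM

Both compounds share one core and a sugar, and differ at the thioether chain and at the amine substituent. In a functional assay on a cell-free system (Platelet, plasma, Homo sapiens) for inhibition, with stated times of 1 min and 3 min (a lower number here means a stronger inhibitor, a higher number a weaker inhibitor), compound 1 gives 197000 nM, and in this assay compound 2 gives 202000 nM. The two numbers lie within the usual scatter of each other, so compound 1 stands level with compound 2 on what has been measured; neither can be called the stronger inhibitor, and both are weak.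

Compound 3, `CCSc1nc(NC2CCCCC2)c2ncn([C@@H]3O[C@H](CO)[C@@H](O)[C@H]3O)c2n1`, has not yet been measured in this assay. Relative to compound 1 the change is cyclohexyl in place of 1-phenylethyl on a nitrogen on an aromatic ring. Among the compounds with values here, no step between two measured compounds isolates this kind of change, so its effect is unknown from these data; the two measured compounds only show that varying the amine substituent and the chain together left the number where it was.

Given that, the step of a 1.0-fold higher number from compound 1 to compound 3 (0.01 log units; within the scatter) is expected to be small, with no clear direction beyond the scatter. Compound 3 is therefore estimated at 200000 nM, within 60000 nM to 650000 nM.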

Compound 3, half-maximal inhibitory concentration: 104000 nM
Estimate against measurement, compound 3: 1.9-fold (0.28 log units) above; measured number inside the range.
By their numbers in this assay, from the lowest: compounds 3, 1 and 2 (each within the scatter of the next).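

Within the data shown here, with the ethyl thioether held fixed, this is the first single-place comparison: cyclohexyl in place of 1-phenylethyl on a nitrogen on an aromatic ring gives, in this assay, a 1.9-fold lower number from compound 1 to compound 3 (0.28 log units; within the scatter). At this position, therefore, a six-membered non-aromatic ring of carbon only reads level with the 1-phenylethyl group, so neither the aromatic ring nor the two further carbon atoms of the group that leaves show any effect on the number beyond the scatter. No measurement at hand offers an explanation for this result.

The separate contribution of the thioether chain cannot be read, since compound 2 differs from each of the other compounds in more than one place, and a butyl chain on the thioether paired with cyclohexylamino would settle that point. Going by these compounds, it also remains open whether a group carrying a hydroxyl or a carboxylic acid on the cyclohexyl ring, or a plain unsubstituted amine at this nitrogen, would move the number beyond the scatter.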